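Replacing the Fluorobenzyl Amide with a Sulfonyl Hydrazide

A few compounds are considered here, and "the series" means these few. Any claim that something is new, unique, unknown or untested is made for them only; others in the source may bear on it.

Compound 1 `CCCNC(=O)COc1ccc2cc(C(O)(C(F)(F)F)C(F)(F)F)c(O)cc2c1` gives > 20000 nM in an assay on isolated protein for inhibition of tyrosine-protein phosphatase non-receptor type 13 (Homo sapiens), read by spectrophotometry (a higher number here means a weaker inhibitor, a lower number a stronger inhibitor), which is a limit of the assay.
Compound 2 `CC(C)c1ccc(NC(=O)COc2ccc3cc(C(O)(C(F)(F)F)C(F)(F)F)c(O)cc3c2)cc1` gives 6500 nM in this assay.
Compound 3 `O=C(COc1ccc2cc(C(O)(C(F)(F)F)C(F)(F)F)c(O)cc2c1)NCc1ccc(F)cc1` gives > 20000 nM in this assay, again only a limit.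

Compound 3 therefore stands at the edge of what this assay can resolve: the limit of > 20000 nM in this assay, at which 2 of the 3 values shown sit. Among the measured compounds shown here, the only readable comparison on it is an at least 3.0-fold higher number from compound 2 to compound 3 (0.48 log units; beyond the scatter); the pair a step that the two limits leave unreadable from compound 1 to compound 3 gives nothing usable. The untested compound 4 `Cc1ccc(S(=O)(=O)NNC(=O)COc2ccc3cc(C(O)(C(F)(F)F)C(F)(F)F)c(O)cc3c2)cc1` differs from compound 3 as ((4-methylphenyl)sulfonyl)amino in place of 4-fluorobenzyl on an amide-type nitrogen. For the measured compounds named here, no measured step exchanges an amide substituent for a sulfonylamino group, so the expectation rests on compound 3 alone. Compound 4 is expected to give 15000 nM, in the range 4000 nM to 40000 nM. The expected step of an at least 1.3-fold lower number from compound 3 to compound 4 (0.12 log units; that floor lies within the scatter) would thus be small, and a further limit rather than a number seems about as likely as not.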

Compound 4, half-maximal inhibitory concentration: 14900 nM
Compound 4: middle estimate off by 1.0-fold (0.00 log units), on the high side; low and high end bracket the measured number.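

With ((4-methylphenyl)sulfonyl)amino on the amide-type nitrogen, the series gains a readable number, and the steps are an at least 1.3-fold lower number from compound 3 to compound 4 (0.12 log units; that floor lies within the scatter) and an at least 1.3-fold lower number from compound 1 to compound 4 (0.12 log units; that floor lies within the scatter), so no real gain can be claimed. Going by these compounds, the true size of these two steps stays unknown because compound 1 and compound 3 stand only at a limit: the limit of > 20000 nM in this assay, at which 2 of the 4 values shown sit. The new group still falls short of 4-isopropylphenyl, with a 2.3-fold higher number from compound 2 to compound 4 (0.36 log units; beyond the scatter).

Open, on these data alone, is whether a carboxylic acid or an amine in place of the methyl of the new group would shift the value.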